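The source may hold more compounds than are shown below. What is called first, only, known or untested is meant among the compounds shown, and "the series" means these compounds.

Measured so far in an assay on isolated protein (kidney, strain Wistar) for displacement of a labelled ligand from Translocator protein (Rattus norvegicus), read by scintillation counting, with a stated time of 90 min; on this read-out lower numbers stand for stronger inhibition and higher numbers for weaker inhibition:

compound 1 `CCN(CC)C(=O)Cc1c(-c2ccc(OC(C)C)cc2)nn2c(C)cc(C)nc12`: 2.2 nM
compound 2 `CCN(CC)C(=O)Cc1c(-c2ccc(OC3CCC3)cc2)nn2c(C)cc(C)nc12`: 0.86 nM

Compound 2 stands at the lower of the two numbers. Going by the values given here, its only neighbour, compound 1, lies higher, and the single step between them, a 2.6-fold lower number from compound 1 to compound 2 (0.41 log units; beyond the scatter), came with cyclobutyl in place of isopropyl on an oxygen on an aromatic ring, a change that stands beyond the usual scatter.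

Compound 3 `CCN(CC)C(=O)Cc1c(-c2ccc(OC3CCCC3)cc2)nn2c(C)cc(C)nc12` has not yet been measured in this assay. It differs from compound 2 in one place: cyclopentyl in place of cyclobutyl on an oxygen on an aromatic ring. Among the compounds with values here, the one measured step that bears on this change is the step from isopropyl to cyclobutyl at the same oxygen, which lowered the number by a modest amount. Growing the ring by one carbon is a smaller change than that, so the expected step, a 1.2-fold lower number from compound 2 to compound 3 (0.09 log units; within the scatter), is a slight further lowering that may well stay within the scatter, and a step in the other direction cannot be ruled out. For compound 3 the expected value in this assay is 0.7 nM, within a range from 0.3 nM to 1.7 nM.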

Compound 3, inhibition constant: 1.5 nM
Compound 3: middle estimate off by 2.1-fold (0.33 log units), on the low side; low and high end bracket the measured number.
By their numbers in this assay, from the lowest: compounds 2, 3 and 1 (each within the scatter of the next, the first and the last beyond it).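

In this assay, enlarging the ring on the oxygen from cyclobutyl to cyclopentyl gives a 1.7-fold higher number from compound 2 to compound 3 (0.24 log units; within the scatter), and setting cyclopentyl against isopropyl gives a 1.5-fold lower number from compound 1 to compound 3 (0.17 log units; within the scatter), so cyclopentyl cannot be told apart from either group, even though those two groups can be told apart from each other. The lowering seen on going from isopropyl to cyclobutyl therefore does not become a steady trend with ring size: among these three groups on the oxygen, only the step from compound 1 to compound 2 lies beyond the scatter, and no further lowering can be read for compound 3. Nothing measured here offers an explanation for these numbers.

The compounds shown leave open what happens at this oxygen with a larger ring such as cyclohexyl, with a longer open chain such as n-butyl, or with a ring that carries an amine. All three compounds also share the diethyl amide and the rest of the core, so they say nothing about changes in those parts.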